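Ester chain variation and expected cell growth inhibition

The source may hold more compounds than are shown below. What is called first, only, known or untested is meant among the compounds shown, and "the series" means these compounds.

Compound 1 `C=C(C)CCOC(=O)C[C@@H]1C(C(=O)OC)=CO[C@@H](O[C@@H]2O[C@H](CO)[C@@H](O)[C@H](O)[C@H]2O)/C1=C/C` has been tested in a functional assay on SK-BR-3 cells (Homo sapiens) for antiproliferative activity, read by MTT assay, with a stated time of 72 h; a lower number here means a stronger inhibitor, a higher number a weaker inhibitor. In this assay compound 1 gives > 15000 nM, which is a limit of the assay rather than a measured number. Compound 1 sits at the limit of > 15000 nM in this assay, at which 1 of the 2 values shown sits. Compound 2 `C/C=C1/[C@H](O[C@@H]2O[C@H](COC(C)=O)[C@@H](OC(C)=O)[C@H](OC(C)=O)[C@H]2OC(C)=O)OC=C(C(=O)O)[C@H]1CC(=O)O` is the second member tested. In this assay compound 2 gives > 20000 nM, again a limit and not a number. Compound 2 sits at the limit of > 20000 nM in this assay, at which 1 of the 2 values shown sits. Among the measured compounds shown here, nothing in these two values separates the compounds, and no step between measured compounds can be drawn from them. Compound 3 `C/C=C1/[C@H](O[C@@H]2O[C@H](CO)[C@@H](O)[C@H](O)[C@H]2O)OC=C(C(=O)OC)[C@H]1CC(=O)OCCc1ccc(F)cc1` has not yet been measured. It differs from compound 1 in one place: 4-fluorophenyl in place of 1-methylethenyl on a saturated chain carbon, two bonds along the chain from an oxygen next to a carbonyl group. With both known values resting at limits, no direction for this change can be read from the series, and the step is expected to stay within the scatter or to move only modestly toward stronger inhibition. For compound 3 the estimate in this assay is 12000 nM, with a range from 3000 nM to 50000 nM. The step of an at least 1.2-fold lower number from compound 1 to compound 3 (0.09 log units; that floor lies within the scatter) is expected to be small, and a limit rather than a number remains the likelier outcome.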

Compound 3, half-maximal inhibitory concentration: > 20000 nM
Compound 3: only a limit was reported; the forecaster's own chance of this, stated with the estimate: 65%; at least 1.6-fold (0.22 log units) between middle value and limit.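

In this assay compound 3 gives > 20000 nM, a limit of the assay and not a number. Among the compounds shown here, compound 1 also rests at a limit, and no step between compound 1 and compound 3 can be read. The compounds shown leave open how the 3-methylbut-3-en-1-yl and 2-(4-fluorophenyl)ethyl chains compare in this assay.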